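A Small Swap on the Ether Side Chain

A few compounds are considered here, and "the series" means these few. Any claim that something is new, unique, unknown or untested is made for them only; others in the source may bear on it.

Measured compounds:
Compound 1, `CCC1(Cc2ccccc2)OS(=O)(=O)C=C1OCCCCc1ccccc1`, gives >= 20000 nM in an ADME assay on HEL cells (Homo sapiens) for cytotoxicity, with a stated time of 3 days; a lower number here means that less compound is tolerated, a higher number that more compound is tolerated; this figure is a limit of the assay, not a number.
Compound 2, `CCC1(Cc2ccccc2)OS(=O)(=O)C=C1OCC(=O)OC`, gives > 400000 nM in this assay; this figure is also a limit, not a number.

Compound 2 therefore stands at the limit of > 400000 nM in this assay, at which 1 of the 2 values shown sits, and nothing more precise is known about it. Within the data shown here, the single measured step, a step that the two limits leave unreadable from compound 1 to compound 2, cannot be given a size because the limit of > 400000 nM in this assay, at which 1 of the 2 values shown sits, and the limit of >= 20000 nM in this assay, at which 1 of the 2 values shown sits, are both limits rather than numbers.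

The next compound, compound 3, `CCC1(Cc2ccccc2)OS(=O)(=O)C=C1OCC#N`, differs from compound 2 by cyano in place of methoxycarbonyl on a saturated chain carbon bound to an oxygen on an unsaturated carbon. Among the measured compounds shown here, no measured step bears directly on this change, so the expectation rests only on where compound 2 stands. Because compound 2 sits at the limit of > 400000 nM in this assay, at which 1 of the 2 values shown sits, compound 3 is expected to be tolerated at a similarly high concentration, with no step beyond the usual scatter in either direction. For compound 3 the estimated value in this assay is 400000 nM, within a range from 100000 nM to 1500000 nM, which corresponds to an expected step of a number no higher from compound 2 to compound 3 (the limit leaves the size open).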

Compound 3, minimum cytotoxic concentration: > 400000 nM
Compound 3: only a limit was reported; the forecaster's own chance of this, stated with the estimate: 70%; the middle value sits exactly at the limit.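

Among these compounds, compound 1, compound 2 and compound 3 all carry limits rather than numbers, and no step among them can be read. The compounds shown leave open how much of each compound is actually tolerated in this assay, and whether cyano in place of methoxycarbonyl changes that tolerated concentration at all.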